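The source may report more compounds than this note shows. Statements on the series, on what has been measured and on what is new or still open speak of the compounds shown alone.

Measured so far:
compound 1 `CN1CCN(c2nc(-c3ccc(Cl)c(Cl)c3)nc3[nH]cnc23)CC1` — > 80%
compound 2 `Clc1ccc(Cl)c(-c2nc(N3CCCCC3)c3nc[nH]c3n2)c1` — 1.4%
compound 3 `CN1CCN(c2nc(-c3ccc(Cl)cc3)nc3[nH]cnc23)CC1` — > 80%

In an assay on cells for displacement of a labelled ligand from adenosine receptor A1 (Homo sapiens), read by scintillation counting and radioligand binding, with a stated time of 60 min, tested at 10 uM (on this read-out higher numbers stand for more inhibition at the one concentration tested (going by the name of the read-out) and lower numbers for less inhibition), compound 1 reaches a limit of the assay, > 80%. Compound 3 likewise sits at a limit of this assay, > 80%. Within the data shown here, the single number in this assay comes from compound 2, with 1.4%. The step that the two limits leave unreadable from compound 1 to compound 3 is made by hydrogen in place of chloro on an aromatic carbon; its size cannot be read, because both ends sit at the limit of > 80% in this assay, at which 2 of the 3 values shown sit. How the core of compound 2 differs from the core of compound 1 is not broken down here.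

Compound 4 `Clc1cccc(-c2nc(N3CCCCC3)c3nc[nH]c3n2)c1` has not been measured in this assay. It arises from compound 2 by hydrogen in place of chloro on an aromatic carbon. This is the same kind of change as from compound 1 to compound 3, but not the same: there the carbon was ortho to a chloro group and meta to a large group, here it is ortho to a large group and para to a chloro group. With no readable size from the earlier step, the expectation for compound 4 rests mainly on compound 2 and its 1.4%: a step of about a number 8.6 percentage points higher from compound 2 to compound 4 (within the scatter) is expected, within the usual scatter. Compound 4 is therefore estimated at 10% in this assay, between 0% and 40%.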

Compound 4, a percentage reported as inhibition, at one concentration (the size of the read-out at that concentration, not a potency): > 80%
Compound 4: only a limit was reported; the forecaster's own chance of this, stated with the estimate: 10%; middle value at least 70 percentage points from the limit.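

In this assay, hydrogen in place of chloro on an aromatic carbon, ortho to a large group and para to a chloro group, gives a number at least 78.6 percentage points higher from compound 2 to compound 4 (beyond the scatter). The value of compound 4, > 80%, is a limit of the assay. The step from compound 1 to compound 3 cannot be read and concerns a carbon in another place, so these compounds do not show that the change carries from one core to another: the limit of > 80% in this assay, at which 3 of the 4 values shown sit.

Open, as far as these compounds go, is whether a fluoro, a methoxy or an amine on the same carbon would read like the hydrogen of compound 4 or like the chloro of compound 2. Also open, from the compounds shown here alone, is any order among compound 1, compound 3 and compound 4, whose values are all limits.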